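Swapping the benzyl substituent from dimethoxy to bromo

The source may report more compounds than this note shows. Statements on the series, on what has been measured and on what is new or still open speak of the compounds shown alone.

Measured compounds:
compound 1 `C=C1CC[C@@H]2[C@](C)(CNCc3ccc(C)cc3)[C@H](O)CC[C@@]2(C)[C@@H]1/C=C/C1=CCOC1=O` — 740 nM
compound 2 `C=C1CC[C@@H]2[C@](C)(CNCc3ccc(OC)cc3)[C@H](O)CC[C@@]2(C)[C@@H]1/C=C/C1=CCOC1=O` — 750 nM
compound 3 `C=C1CC[C@@H]2[C@](C)(CNCc3ccc(OC)c(OC)c3)[C@H](O)CC[C@@]2(C)[C@@H]1/C=C/C1=CCOC1=O` — 3740 nM

Three compounds share a core and differ only in the aryl group on the benzylamine. In a functional assay on BMMC cells (Mus musculus, strain C57BL/6) for inhibition, with stated times of 5 days and 48 h (on this read-out higher numbers stand for weaker inhibition and lower numbers for stronger inhibition), compound 1 gives 740 nM and compound 2 gives 750 nM; the step of a 1.0-fold higher number from compound 1 to compound 2 (0.01 log units; within the scatter) lies within the scatter. Compound 3, carrying the 3,4-dimethoxyphenyl, stands highest of the three, with a 5.1-fold higher number from compound 1 to compound 3 (0.70 log units; beyond the scatter) and a 5.0-fold higher number from compound 2 to compound 3 (0.70 log units; beyond the scatter) both beyond the scatter.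

Compound 4 `C=C1CC[C@@H]2[C@](C)(CNCc3ccc(Br)cc3)[C@H](O)CC[C@@]2(C)[C@@H]1/C=C/C1=CCOC1=O` has not yet been measured. It differs from compound 3 as follows: 4-bromophenyl in place of 3,4-dimethoxyphenyl on a saturated chain carbon bound to an amine nitrogen. Among the compounds with values here, two measured steps bear on this. The step of a 5.0-fold higher number from compound 2 to compound 3 (0.70 log units; beyond the scatter) shows that adding the second methoxy raised the number modestly; compound 4 lacks that methoxy, so the reverse is expected. The step of a 1.0-fold higher number from compound 1 to compound 2 (0.01 log units; within the scatter) shows that exchanging one group on the aromatic carbon for another left the number essentially unchanged, and bromine in the same position is expected to behave alike.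

Compound 4 is therefore expected to fall back to roughly where compound 1 and compound 2 sit, an expected step of a 5.0-fold lower number from compound 3 to compound 4 (0.70 log units; beyond the scatter). The estimate for compound 4 is 750 nM, with a range from 350 nM to 1600 nM.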

Compound 4, half-maximal inhibitory concentration: 430 nM
For compound 4 the middle estimate is 1.7-fold (0.24 log units) above the measured one; low and high end bracket the measured number.
By their numbers in this assay, from the lowest: compounds 4, 1 and 2 (each within the scatter of the next); then compound 3.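

In this assay, replacing 3,4-dimethoxyphenyl with 4-bromophenyl on a saturated chain carbon bound to an amine nitrogen gives an 8.7-fold lower number from compound 3 to compound 4 (0.94 log units; beyond the scatter), showing that a group with no methoxy at all can also leave the high number of compound 3 behind. The comparisons with the other two compounds, a 1.7-fold lower number from compound 2 to compound 4 (0.24 log units; within the scatter) and a 1.7-fold lower number from compound 1 to compound 4 (0.24 log units; within the scatter), both lie within the scatter, so bromo, methoxy and methyl on the aromatic carbon cannot be told apart in this read-out, and among these four compounds only the 3,4-dimethoxyphenyl group of compound 3 stands apart. Nothing measured here accounts for this difference, and the tolerance seen so far rests on only these three aryl groups.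

The compounds shown leave open whether the higher number of compound 3 belongs to the two methoxy groups specifically or would also appear with another doubly substituted ring such as 3,4-dichlorophenyl. They also leave open whether the unsubstituted phenyl, or a 4-substituted ring carrying a carboxylic acid or an amine, would read like compound 4 or move away from it.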